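This account rests on a few compounds, and the source may have more. Where it says the series, first, only, none or still open, it means among the compounds named here.

In a functional assay on MCF7 cells (Homo sapiens) for cytotoxicity, read by MTT assay, with a stated time of 24 h (a higher number here means a weaker inhibitor, a lower number a stronger inhibitor), compound 1 `Cc1cc(O)c(C(=O)/C=C/c2ccc(Cl)cc2)c(-c2ccc(Cl)cc2)c1C(=O)/C=C/c1ccc(Cl)cc1` gives 28000 nM. Compound 2 `Cc1cc(O)c(C(=O)/C=C/c2ccc3ccccc3c2)c(-c2ccc(Cl)cc2)c1C(=O)/C=C/c1ccc2ccccc2c1` is reported in this assay as "not active" (no number reported), so no single number exists to place it; it stands only as a compound without a measured concentration. Compound 3 `Cc1cc(O)c(C(=O)/C=C/c2ccc3ccccc3c2)c(-c2ccccc2)c1C(=O)/C=C/c1ccc2ccccc2c1` differs from compound 2 by hydrogen in place of chloro on an aromatic carbon. Going by the values given here, with no measured step covering this change, the expected shift in this assay is small, in no set direction, and not beyond the usual scatter. Compound 3 is therefore expected to give about 60000 nM in this assay, with a range from 15000 nM to 250000 nM, and a real chance that only an inactive result is reported again.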

Compound 3, half-maximal inhibitory concentration: 31500 nM
Compound 3: the middle estimate sits 1.9-fold (0.28 log units) above what was measured, within the range that was stated.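

Going by these compounds alone, compound 2 has no number, so the change from 4-chlorophenyl to phenyl that gives compound 3 yields no step that can be read. How much that change shifts cytotoxicity stays open, and no measurement here offers an explanation.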